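The source may report more compounds than this note shows. Statements on the series, on what has been measured and on what is new or still open speak of the compounds shown alone.

The series rests on a shared core, shown in compound 1 `C#CCOc1ccc(/C=C/C(=O)c2ccc(Br)cc2)cc1` and compound 2 `C#CCOc1ccc(/C=C/C(=O)c2ccc(OC)cc2)cc1` and extended in compound 3 `O=C(/C=C/c1ccc(OCc2cn(Cc3ccccc3Br)nn2)cc1)c1ccc(Br)cc1`. In a functional assay on A549 cells (Homo sapiens) for inhibition, read by MTT assay, with a stated time of 48 h, tested at 10 uM (on this read-out lower numbers stand for less inhibition of growth and higher numbers for more inhibition of growth at the one concentration tested), compound 1 gives 34%. In this assay compound 2 gives 27%; the step is a number 7 percentage points lower from compound 1 to compound 2 (within the scatter), methoxy in place of bromo on an aromatic carbon. In this assay compound 3 gives 44%, the highest of the three numbers, within the scatter of compound 1 and beyond the scatter of compound 2, so no order between compound 3 and compound 1 can be claimed.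

Compound 4 `O=C(/C=C/c1ccc(OCc2cn(Cc3ccccc3F)nn2)cc1)c1ccc(Br)cc1` has not yet been measured. It differs from compound 3 in one place: fluoro in place of bromo on an aromatic carbon, ortho to a large group; cut one bond further out, the change reads 2-bromobenzyl to 2-fluorobenzyl. Within the data shown here, the only measured step exchanges bromo for methoxy on a different ring and stays within the scatter; no measured step exchanges one halogen for another, and none touches the benzyl part of compound 3. The step is therefore expected to be a number 4 percentage points lower from compound 3 to compound 4 (within the scatter), nothing beyond the scatter in either direction. Compound 4 is expected to give about 40% in this assay, with a range from 25% to 55%.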

Compound 4, percent growth inhibition at one concentration: 38%
Beside the measured number, compound 4's estimate is 2 percentage points above it; measured number inside the range.
By their numbers in this assay, from the lowest: compounds 2, 1, 4 and 3 (each within the scatter of the next, the first and the last beyond it).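

Among these compounds, with fluoro in place of bromo on an aromatic carbon ortho to a large group, the step is a number 6 percentage points lower from compound 3 to compound 4 (within the scatter) in this assay, and it is the first measured step on the benzyl part and the first to exchange one halogen for another. Among the compounds shown here, it shows that 2-fluorobenzyl can stand for 2-bromobenzyl without a change that can be read, so no order between the two compounds can be claimed, and the earlier compounds, which varied only the bromo or methoxy on the other ring, could not show this. No measured data bear on the reason for this result, and none is offered.

The compounds shown leave open whether a group of another kind at this place, such as an amine, a carboxylic acid or a longer chain, would give a step beyond the scatter, since only two halogens have stood there. They also leave open whether the exchange of bromo for fluoro on the benzyl part would read the same with the methoxy of compound 2 in place of the bromo that compound 3 and compound 4 share.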